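The compounds below may be only part of what the source reports. "The series", "measured", "known", "first", "only" and "open" are said of these compounds alone.

Compound 1, `CN(C)C(=O)c1ccc(-c2cc(C3=CC(=O)C=CC3=O)no2)s1`, was tested in a functional assay on PC-3 cells (Homo sapiens) for cytotoxicity, read by XTT assay, with a stated time of 72 h (on this read-out higher numbers stand for weaker inhibition and lower numbers for stronger inhibition), and compound 1 gives 7200 nM. Compound 2, `CCCN(C)C(=O)c1ccc(-c2cc(-c3cc(OC)ccc3OC)no2)s1`, belongs to the same series; in this assay compound 2 reaches only a limit, > 30000 nM. Within the data shown here, of the two values recorded, the one for compound 1 is the only number, since the other is the limit of > 30000 nM in this assay, at which 1 of the 2 values shown sits.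

Compound 3, `O=C1C=CC(=O)C(c2cc(-c3ccc(C(=O)N4CCCC4)s3)on2)=C1`, is not yet measured. Compound 3 differs from compound 1 in one place: pyrrolidin-1-yl in place of dimethylamino on a carbonyl carbon. Everything else in the molecule is kept, so the change is confined to the amide on the side of the core that carries the carbonyl. No measured pair describes a step of this kind here, and there is no evidence to point to a cause for any effect. The step from compound 1 to compound 3 is expected to be small, a 1.1-fold lower number from compound 1 to compound 3 (0.04 log units; within the scatter), not beyond the usual scatter in either direction. Compound 3 is therefore estimated at 6500 nM, with a range from 2500 nM to 16000 nM.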

Compound 3, half-maximal inhibitory concentration: < 30000 nM
Compound 3 was reported as a limit; the forecaster's own chance of this, stated with the estimate: 5%; the middle value is on the limit's open side.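

In this assay compound 3 gives < 30000 nM as a limit and not a number. Among these compounds, no step from compound 1 to compound 3 can therefore be read. From the compounds shown here alone, whether pyrrolidin-1-yl in place of dimethylamino on a carbonyl carbon changes the cytotoxic strength, and in which direction, stays open.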